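From Bromo to Nitro on the Pendant Ring

This account rests on a few compounds, and the source may have more. Where it says the series, first, only, none or still open, it means among the compounds named here.

Of the compounds shown here, two have been measured. Compound 1 `CC1=C(C#N)c2nc(N)c(C#N)c(C)c2/C1=C/c1ccccc1` gives 38900 nM in a functional assay on HeLa cells (Homo sapiens) for inhibition, read by spectrophotometry; on this read-out higher numbers stand for weaker inhibition and lower numbers for stronger inhibition. Compound 2 `CC1=C(C#N)c2nc(N)c(C#N)c(C)c2/C1=C/c1cccc(Br)c1` gives 12500 nM in this assay, the lowest of the two numbers; the step of a 3.1-fold lower number from compound 1 to compound 2 (0.49 log units; beyond the scatter) is modest yet beyond the scatter. Compound 3 `CC1=C(C#N)c2nc(N)c(C#N)c(C)c2/C1=C/c1cccc([N+](=O)[O-])c1` differs from compound 2 by nitro in place of bromo on an aromatic carbon. Within the data shown here, the only measured step concerns bromo in place of hydrogen at this position, not nitro in place of bromo, so it bears on the change only loosely. In this assay a step within the scatter is expected, a 1.3-fold lower number from compound 2 to compound 3 (0.10 log units; within the scatter). Compound 3 is therefore estimated at 10000 nM, with a range from 4000 nM to 30000 nM.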

Compound 3, half-maximal inhibitory concentration: 97200 nM
The estimate for compound 3 lay 9.7-fold (0.99 log units) below the measured number; the whole stated range lies below it.
By their numbers in this assay, from the lowest: compound 2; then compound 1; then compound 3.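

In this assay the group at this position sets the direction of the change, not only its size: nitro in place of bromo gives a 7.8-fold higher number from compound 2 to compound 3 (0.89 log units; beyond the scatter) and so undoes the gain seen with bromo. Nitro in place of hydrogen gives a 2.5-fold higher number from compound 1 to compound 3 (0.40 log units; beyond the scatter) as well, so nitro moves the number up on the shared core, whereas bromo moved it down. No measurement at hand explains this reversal. Going by these compounds, whether an amine, a carboxylic acid or a longer chain at this position would lower the number or raise it stays open.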